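The source may hold more compounds than are shown below. What is called first, only, known or untested is meant among the compounds shown, and "the series" means these compounds.

For the measured compounds named here, compound 1 `CCCn1ncnc1-c1ccccc1NCC1=NCCN1` is the only compound in this set that stands at a definite number: in an in vitro functional assay on cells (Fibroblast) for agonist activity at Alpha-1B adrenergic receptor (Homo sapiens) (on this read-out higher numbers stand for an effect only at larger amounts of compound and lower numbers for an effect already at smaller amounts), compound 1 gives 316 nM. Compound 2 `Cc1nc(-c2ccccc2NCC2=NCCN2)n(C)n1` has in this assay only a limit of the assay, < 5020 nM, and not a number. Going by the values given here, the one further value shown is thus (the limit of < 5020 nM in this assay, at which 1 of the 2 values shown sits), so no step between two measured compounds can be taken from these two, and compound 1 has nothing to be ranked against. Compound 3 `CCCCn1ncnc1-c1ccccc1NCC1=NCCN1` is not yet measured in this assay. It differs from compound 1 in one place: methyl in place of hydrogen on a saturated chain carbon, three bonds along the chain from an aromatic nitrogen. Cut one bond further out, the change reads propyl to butyl, and the data hold no measured step on which the effect of such a lengthening could be read. In this assay the step from compound 1 to compound 3 is therefore expected to be small, within the usual scatter, and its direction cannot be told; the expected step is a 1.1-fold higher number from compound 1 to compound 3 (0.04 log units; within the scatter). Compound 3 is estimated in this assay at 350 nM, with a range from 120 nM to 1000 nM.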

Compound 3, half-maximal effective concentration: 200 nM
Compound 3: the middle estimate sits 1.8-fold (0.24 log units) above what was measured; measured number inside the range.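

For the compounds shown here, this is the first measured step at this position: on the chain from the aromatic nitrogen, the propyl of compound 1 becomes the butyl of compound 3, with methyl in place of hydrogen on the saturated chain carbon three bonds along (a 1.6-fold lower number from compound 1 to compound 3 (0.20 log units; within the scatter)). In this assay, this step lies within the usual scatter, so compound 1 and compound 3 cannot be told apart, and the chain can carry this one added carbon without a measurable shift in the read-out. No measurement shown gives a cause for this step.

Compound 2 stands only at a limit of the assay (< 5020 nM), not at a number, and so offers no further reading. Going by these compounds, what a chain longer than butyl would do in this assay stays open, as does the effect of an amine or a carboxylic acid at the end of the chain, and this single step says nothing about the shorter lengthenings from methyl to ethyl or from ethyl to propyl.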